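Cytotoxicity notes: from compound 2 to compound 3

The source may report more compounds than this note shows. Statements on the series, on what has been measured and on what is new or still open speak of the compounds shown alone.

- compound 1 `COc1ccc(-c2nc3c(NC4CCCC4)cccn3c2-c2ccnc(NC3CCCC3)n2)cc1` gives > 10000 nM (a limit of the assay)
- compound 2 `Fc1ccc(-c2nc3c(NC4CC4)cccn3c2-c2ccnc(NC3CCCC3)n2)cc1` gives 33000 nM (a measured number)

In an ADME assay on Vero cells (Chlorocebus sabaeus) for cytotoxicity (on this read-out lower numbers stand for higher toxicity in this test and higher numbers for lower toxicity in this test), compound 2 gives 33000 nM as the only number shown so far. Compound 1 stands at the limit of > 10000 nM in this assay, at which 1 of the 2 values shown sits, and nothing more than that limit is known for it.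

The next compound to be read is compound 3 `Fc1ccc(-c2nc3c(C4CCCC4)cccn3c2-c2ccnc(NC3CCCC3)n2)cc1`, which carries cyclopentyl in place of cyclopropylamino on an aromatic carbon two atoms from the ring nitrogen. The rest of the structure is the same as in compound 2.

Within the data shown here, no measured step covers this exchange, so there is no direct guide to its size in this assay. The expectation starts from compound 2 at 33000 nM and allows a small move toward lower numbers. The estimated change is a 1.3-fold lower number from compound 2 to compound 3 (0.12 log units; within the scatter) and it is expected to stay within the usual scatter. For compound 3 the expected value is 25000 nM, with an estimated range from 10000 nM to 60000 nM in this read-out.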

Compound 3, half-maximal cytotoxic concentration: > 40000 nM
Compound 3: no number, only a limit (the forecaster's own chance of this, stated with the estimate: 35%); middle value at least 1.6-fold (0.20 log units) away from the limit.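

In this assay, among these compounds, the exchange of cyclopropylamino for cyclopentyl on an aromatic carbon two atoms from the ring nitrogen gives the first readable step at this position, an at least 1.2-fold higher number from compound 2 to compound 3 (0.08 log units; that floor lies within the scatter). As far as these compounds go, compound 3 is recorded only as a limit of the assay, > 40000 nM, so the true size of the step remains unknown. The exchange removes the hydrogen-bond donor and acceptor counted for cyclopropylamino and adds a carbon-only five-membered ring, yet no move to lower numbers appears in this read-out, and the limit sets how far that reading goes: the limit of > 40000 nM in this assay, at which 1 of the 3 values shown sits.

Compound 1 differs from the other compounds in more than one place, so its limit gives no readable step, and the effect of the cyclopentyl group cannot be separated from the assay ceiling. Open questions are whether a more polar group on this aromatic carbon, such as a morpholine ring, a primary amine or a carboxylic acid, would give a true number in this assay, and whether a longer alkyl chain would read as cyclopentyl does.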